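From Anilino to Cyclopentylamino on a Weak Kinase Inhibitor

This account rests on a few compounds, and the source may have more. Where it says the series, first, only, none or still open, it means among the compounds named here.

In an assay on cells for inhibition of serine/threonine-protein kinase WNK1 (Homo sapiens), read by luminescence and Kinase-Glo, with a stated time of 2 h (a higher number here means a weaker inhibitor, a lower number a stronger inhibitor), compound 2 `O=[N+]([O-])c1cc(S(=O)(=O)C(Cl)(Cl)Br)ccc1Nc1ccccc1` gives 76000 nM. That is the lowest of the two numbers available, but the margin is slight: compound 3 `O=[N+]([O-])c1cc(S(=O)(=O)C(Cl)(Cl)Br)ccc1NCCCCc1ccccc1` gives 79000 nM, and the two values lie within the scatter of each other, so neither can be called the stronger inhibitor. Compound 1 `O=[N+]([O-])c1ccccc1NC1CCCCC1` returns no number at all in this assay but only a limit, > 1000000 nM. Compound 1 thus sits at the limit of > 1000000 nM in this assay, at which 1 of the 3 values shown sits.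

Compound 4 `O=[N+]([O-])c1cc(S(=O)(=O)C(Cl)(Cl)Br)ccc1NC1CCCC1` has not yet been measured. It differs from compound 2 in one place: cyclopentyl in place of phenyl on a nitrogen on an aromatic ring. Two different groups on that nitrogen, the phenyl of compound 2 and the phenylbutyl of compound 3, give values that cannot be told apart, which suggests the assay is not very sensitive to what hangs on that nitrogen as long as the rest of the molecule stays the same. Compound 1, carrying a saturated ring on the nitrogen, offers no guidance here, since it lacks the other groups the three sulfone-bearing compounds share. For compound 4 the expectation is therefore a step of a 1.3-fold higher number from compound 2 to compound 4 (0.12 log units; within the scatter), that is, no change beyond the scatter. Compound 4 is estimated to give 100000 nM in this assay, within a range of 30000 nM to 400000 nM.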

Compound 4, half-maximal inhibitory concentration: 93000 nM
Compound 4: middle estimate off by 1.1-fold (0.03 log units), on the high side; the measured number falls inside the stated range.
By their numbers in this assay, from the lowest: compounds 2, 3 and 4 (each within the scatter of the next). At a limit, above all of these: compound 1.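

In this assay, cyclopentyl in place of phenyl on a nitrogen on an aromatic ring gives a 1.2-fold higher number from compound 2 to compound 4 (0.09 log units; within the scatter), so this swap leaves the number inside the scatter. For the compounds shown here, this is the first step read between two measured compounds, and it shows that at this position, for this pair, a five-membered non-aromatic ring of carbon and a six-membered aromatic ring of carbon cannot be told apart, even though one carbon is lost along with the aromatic ring. Nothing measured here bears on why the two rings read alike.

From the compounds shown here alone, what remains open is whether any group on this nitrogen can move the number beyond the scatter, for instance a small methyl, a cyclohexyl ring, or a phenyl ring carrying a carboxylic acid or an amine. Compound 1 differs from the others in more than one place, so it cannot show what the sulfone part of the shared core contributes, and a compound with a cyclopentyl on the nitrogen but no sulfone would be needed to separate that part from the ring.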